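This account rests on a few compounds, and the source may have more. Where it says the series, first, only, none or still open, it means among the compounds named here.

Compounds measured so far in an assay on CHO cells for displacement of a labelled ligand from adenosine receptor A2b (Homo sapiens), read by scintillation counting, with a stated time of 75 min, in the presence of a further agent that is not named here; on this read-out higher numbers stand for weaker inhibition and lower numbers for stronger inhibition:
- compound 1 `CCCn1c(=O)[nH]c2nc(-c3ccc(S(=O)(=O)N4CCN(C)CC4)cc3)[nH]c2c1=O` gives 48.2 nM
- compound 2 `CCCn1c(=O)[nH]c2nc(-c3ccc(S(=O)(=O)N4CCN(c5ccccc5)CC4)cc3)[nH]c2c1=O` gives 0.643 nM
- compound 3 `CCCn1c(=O)[nH]c2nc(-c3ccc(S(=O)(=O)N4CCN(c5cccc(Cl)c5)CC4)cc3)[nH]c2c1=O` gives 0.342 nM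

Compound 3 shows the lowest number of the three, but its nearest neighbour, compound 2, is within the usual scatter, so the two cannot be ordered; only compound 1 stands apart, with a 140-fold lower number from compound 1 to compound 3 (2.15 log units; beyond the scatter). Compound 4 `CCCn1c(=O)[nH]c2nc(-c3ccc(S(=O)(=O)N4CCN(c5ccc(C)cc5)CC4)cc3)[nH]c2c1=O` is not yet measured. It differs from compound 3 by 4-methylphenyl in place of 3-chlorophenyl on an amine nitrogen in a ring. Among the compounds with values here, two steps bear on this. Replacing methyl on the ring amine nitrogen by an aryl group gave a 75-fold lower number from compound 1 to compound 2 (1.87 log units; beyond the scatter) and a 140-fold lower number from compound 1 to compound 3 (2.15 log units; beyond the scatter), while exchanging hydrogen for chloro on that aryl gave only a 1.9-fold lower number from compound 2 to compound 3 (0.27 log units; within the scatter). Since compound 4 keeps an aryl group on that nitrogen, no step beyond the scatter is expected, and compound 4 is estimated at 0.55 nM (range 0.2 nM to 1.6 nM), meaning an expected step of a 1.6-fold higher number from compound 3 to compound 4 (0.21 log units; within the scatter).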

Compound 4, inhibition constant: 0.706 nM
Compound 4: the middle estimate sits 1.3-fold (0.11 log units) below what was measured; measured number inside the range.
By their numbers in this assay, from the lowest: compounds 3, 2 and 4 (each within the scatter of the next, the first and the last beyond it); then compound 1.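

In this assay, 4-methylphenyl keeps nearly all of the large difference from the methyl group of the first compound, with a 68-fold lower number from compound 1 to compound 4 (1.83 log units; beyond the scatter), so a third aryl group on the ring amine nitrogen behaves like the other two. Adding a methyl group to the phenyl ring gives a 1.1-fold higher number from compound 2 to compound 4 (0.04 log units; within the scatter), yet 4-methylphenyl in place of 3-chlorophenyl gives a 2.1-fold higher number from compound 3 to compound 4 (0.31 log units; beyond the scatter), the first modest separation among these aryl groups. Nothing available here accounts for that separation. Open, going by these compounds, is whether a methoxy group, an amine or a carboxylic acid on the phenyl ring would hold these low numbers. Also open, on these data alone, is whether a benzyl group on that nitrogen would do so.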